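This account rests on a few compounds, and the source may have more. Where it says the series, first, only, none or still open, it means among the compounds named here.

In a functional assay on HCT-116 cells (Homo sapiens) for cytotoxicity, read by MTT assay, with a stated time of 48 h, in the presence of a further agent that is not named here (a lower number here means that less compound is needed, a higher number that more compound is needed for the effect), compound 1 `Cc1nn(C)c2nc(NNC(=O)Nc3cc(Cl)nc(Cl)c3)cc(C3CC3)c12` with cyclopropyl gives 67700 nM and compound 2 `COc1ccc(-c2cc(NNC(=O)Nc3cc(Cl)nc(Cl)c3)nc3c2c(C)nn3C)cc1` with 4-methoxyphenyl gives 82300 nM at the same place on the shared core. Compound 3 `Cc1nn(C)c2nc(NNC(=O)Nc3cc(Cl)nc(Cl)c3)cc(C3CCCCC3)c12` carries cyclohexyl there, gives 38000 nM and stands apart from compound 2 alone. For the measured compounds named here, that separation is modest, with a 2.2-fold lower number from compound 2 to compound 3 (0.34 log units; beyond the scatter) as the only step beyond the scatter, while a 1.8-fold lower number from compound 1 to compound 3 (0.25 log units; within the scatter) and a 1.2-fold higher number from compound 1 to compound 2 (0.08 log units; within the scatter) both stay within it.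

Compound 4 `Cc1cc(NNC(=O)Nc2cc(Cl)nc(Cl)c2)nc2c1c(C)nn2C` differs from compound 3 by methyl in place of cyclohexyl on an aromatic carbon with methyl in place of cyclohexyl on an aromatic carbon opposite the ring nitrogen. Going by the values given here, no measured compound has methyl there, so the three steps bear on this change only indirectly. Exchanges among the measured groups have moved the numbers little, and the closest guide is compound 1 with cyclopropyl, the smallest of those groups, at 67700 nM on the measured scale. The expectation is therefore a 1.7-fold higher number from compound 3 to compound 4 (0.23 log units; within the scatter) as a small move toward a higher number that stays within the scatter. Compound 4 is estimated at 65000 nM with a range from 30000 nM to 140000 nM expected for it.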

Compound 4, half-maximal effective concentration: > 100000 nM
Compound 4: no number, only a limit; the forecaster's own chance of this, stated with the estimate: 10%; at least 1.5-fold (0.18 log units) between middle value and limit.
By their numbers in this assay, from the lowest: compounds 3, 1 and 2 (each within the scatter of the next, the first and the last beyond it). At a limit, above all of these: compound 4.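

In this assay compound 4, whose methyl is the only group of the four at this place without a ring, gives a limit and not a number: the limit of > 100000 nM in this assay, at which 1 of the 4 values shown sits.

For the compounds shown here, replacing cyclohexyl with methyl on this aromatic carbon opposite the ring nitrogen gives an at least 2.6-fold higher number from compound 3 to compound 4 (0.42 log units; beyond the scatter), a floor that already exceeds the only step beyond the scatter among the earlier compounds, so the result adds a clear loss that those exchanges between ring-bearing groups did not show. Going by these compounds alone, the comparisons with the other two compounds are less firm, with an at least 1.2-fold higher number from compound 2 to compound 4 (0.08 log units; that floor lies within the scatter) and an at least 1.4-fold higher number from compound 1 to compound 4 (0.16 log units; that floor lies within the scatter), so only the step from cyclohexyl establishes a change at this position.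

The limit leaves the full size of all three steps open, and with a single group lacking a ring, the compounds shown cannot tell whether the ring itself or simply the number of heavy atoms matters here. From the compounds shown here alone, whether an ethyl group or a longer chain such as n-butyl would behave like methyl or like cyclohexyl also stays open, as does the effect of an amine at this place.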